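A few compounds are considered here, and "the series" means these few. Any claim that something is new, unique, unknown or untested is made for them only; others in the source may bear on it.

Compound 1 `COc1cc(-c2cc(=O)c3cc(O)ccc3o2)cc(OC)c1OC` and compound 2 `COc1cc(-c2cc(=O)c3cc(O)ccc3o2)cc(OC)c1O[Si](C)(C)C(C)(C)C` share one core and differ only on a single oxygen. In a functional assay on SK-MEL cells (Homo sapiens) for cytotoxicity, read by MTT assay, with a stated time of 6 days (on this read-out higher numbers stand for an effect only at larger amounts of compound and lower numbers for an effect already at smaller amounts), compound 1 gives 5.87 ug/mL and compound 2 gives 2.95 ug/mL and so stands level with compound 1 within the scatter. Relative to compound 2, compound 3 `COc1cc(-c2cc(=O)c3cc(O)ccc3o2)cc(OC)c1O` carries the change a hydrogen atom in place of a group of 7 heavy atoms (6 carbon, 1 silicon; no ring), on an oxygen on an aromatic ring and the rest of the structure stays the same. For the measured compounds named here, the one measured step at that oxygen is a 2.0-fold lower number from compound 1 to compound 2 (0.30 log units; within the scatter) and it stays within the scatter. Going by the values given here, no measured compound has a hydrogen on that oxygen, so the support is thin. In this assay no step beyond the scatter is therefore expected, and the estimated step is a 1.5-fold higher number from compound 2 to compound 3 (0.18 log units; within the scatter) with only a weak lean in that direction. For compound 3 the estimated value is 4.5 ug/mL with an expected range from 1.8 ug/mL to 11 ug/mL in repeated measurements.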

Compound 3, concentration for half-maximal effect: 5.68 ug/mL
The estimate for compound 3 lay 1.3-fold (0.10 log units) below the measured number; low and high end bracket the measured number.
By their numbers in this assay, from the lowest: compounds 2, 3 and 1 (each within the scatter of the next).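

In this assay, this oxygen on an aromatic ring now has hydrogen as a third substituent alongside methyl and the silicon-bearing group of 7 heavy atoms. Taking off that silicon-bearing group gives a 1.9-fold higher number from compound 2 to compound 3 (0.28 log units; within the scatter), and hydrogen in place of methyl gives a 1.0-fold lower number from compound 1 to compound 3 (0.01 log units; within the scatter), so all three substituents at this oxygen lie within the scatter of one another and no substituent here yet separates from the others. No supporting data bear on why the numbers at this oxygen stay so close.

Going by these compounds, whether an aminoethyl group, a carboxymethyl group or a longer alkyl chain on this oxygen would give a step beyond the scatter remains open. Also open, on these data alone, is whether a change elsewhere on the shared core would do so in this assay.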